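A few compounds are considered here, and "the series" means these few. Any claim that something is new, unique, unknown or untested is made for them only; others in the source may bear on it.

The three measured compounds in a functional assay on HCT-116 cells (Homo sapiens) for inhibition, read by MTT assay, with a stated time of 72 h; on this read-out higher numbers stand for weaker inhibition and lower numbers for stronger inhibition:

compound 1, `COc1cc(Oc2cccc(Nc3ccccc3)c2)cc(OC)c1CNCc1ccccc1`: 4070 nM
compound 2, `COc1cc(Oc2cccc(Nc3ccccc3)c2)cc(OC)c1CNCc1ccc(F)cc1`: 4220 nM
compound 3, `COc1cc(Oc2cccc(Nc3ccccc3)c2)cc(OC)c1CNCc1ccc(C)cc1`: 13800 nM

In this assay compound 2 stands second highest of the three numbers; its nearest neighbour is compound 1, with a 1.0-fold higher number from compound 1 to compound 2 (0.02 log units; within the scatter), and its furthest is compound 3, with a 3.3-fold higher number from compound 2 to compound 3 (0.51 log units; beyond the scatter).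

Compound 4, `CCN1CCN(Cc2c(OC)cc(Oc3cccc(Nc4ccccc4)c3)cc2OC)CC1`, differs from compound 2 in one place: 4-ethylpiperazin-1-yl in place of (4-fluorobenzyl)amino on a saturated chain carbon bound to an aromatic carbon. Going by the values given here, no measured step touches this position. The three steps known — a 1.0-fold higher number from compound 1 to compound 2 (0.02 log units; within the scatter), a 3.4-fold higher number from compound 1 to compound 3 (0.53 log units; beyond the scatter) and a 3.3-fold higher number from compound 2 to compound 3 (0.51 log units; beyond the scatter) — all concern hydrogen, fluoro or methyl on an aromatic carbon and are at most modest. Among the compounds with values here, with no precedent for this change, the expected step is a 1.2-fold higher number from compound 2 to compound 4 (0.07 log units; within the scatter), carrying wide uncertainty. Compound 4 is therefore estimated at 5000 nM, ranging from 1500 nM to 17000 nM.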

Compound 4, half-maximal inhibitory concentration: > 20000 nM
Compound 4: only a limit was reported; the forecaster's own chance of this, stated with the estimate: 5%; middle value at least 4.0-fold (0.60 log units) from the limit.
By their numbers in this assay, from the lowest: compounds 1 and 2 (each within the scatter of the next); then compound 3. At a limit, above all of these: compound 4.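

Compound 4 is read only as a limit in this assay: the limit of > 20000 nM in this assay, at which 1 of the 4 values shown sits. Replacing the benzylamino-type group on this saturated chain carbon with 4-ethylpiperazin-1-yl gives an at least 4.7-fold higher number from compound 2 to compound 4 (0.67 log units; beyond the scatter) and an at least 4.9-fold higher number from compound 1 to compound 4 (0.69 log units; beyond the scatter), so this position does respond to change, and the step is not confined to the aromatic ring substituents seen earlier. The third comparison gives an at least 1.4-fold higher number from compound 3 to compound 4 (0.16 log units; that floor lies within the scatter), so that floor does not separate compound 4 from compound 3.

As far as these compounds go, the true size of these steps stays open, as does which part of the exchanged group matters. A morpholine or a plain dimethylamino group on the same carbon would help to separate the two.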